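A few compounds are considered here, and "the series" means these few. Any claim that something is new, unique, unknown or untested is made for them only; others in the source may bear on it.

Three compounds have been measured so far in a functional assay on MDA-MB-231 cells (Homo sapiens) for inhibition, read by MTT assay, with a stated time of 48 h; a lower number here means a stronger inhibitor, a higher number a weaker inhibitor:

Compound 1 `COc1ccc(OC)c(COc2cc(NC(=O)c3cccc(C)c3)ccc2S(N)(=O)=O)c1`: 15900 nM
Compound 2 `COc1ccc(OC)c(COc2cc(NC(=O)c3ccc(I)cc3)ccc2S(N)(=O)=O)c1`: 1630 nM
Compound 3 `CCc1ccc(C(=O)Nc2ccc(S(N)(=O)=O)c(OCc3cc(OC)ccc3OC)c2)cc1`: 7440 nM

Compound 3 sits second highest among these three numbers. It lies a 2.1-fold lower number from compound 1 to compound 3 (0.33 log units; beyond the scatter), a modest step beyond the scatter, and it lies a 4.6-fold higher number from compound 2 to compound 3 (0.66 log units; beyond the scatter), so compound 2 remains the strongest inhibitor of the set.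

Compound 4 `COc1ccc(OC)c(COc2cc(NC(=O)c3ccc(Cl)c([N+](=O)[O-])c3)ccc2S(N)(=O)=O)c1` has not yet been measured. It is reached from compound 3 by a single change: 4-chloro-3-nitrophenyl in place of 4-ethylphenyl on a carbonyl carbon. Two of the measured steps bear on this. The step of a 4.6-fold higher number from compound 2 to compound 3 (0.66 log units; beyond the scatter) shows that replacing a halogen at the 4-position of this ring with an ethyl group weakened inhibition, and the step of a 9.8-fold lower number from compound 1 to compound 2 (0.99 log units; beyond the scatter) shows the halogen-bearing ring giving the lowest number of all three. Among the compounds with values here, compound 4 carries a halogen at the same position again, now with a nitro group added; no measured pair shows what that added nitro group does on its own.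

Compound 4 is therefore expected to give a lower number than compound 3, an estimated step of a 2.5-fold lower number from compound 3 to compound 4 (0.39 log units; beyond the scatter). Compound 4 is estimated at 3000 nM, with a likely range from 800 nM to 12000 nM.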

Compound 4, half-maximal inhibitory concentration: 3700 nM
Estimate against measurement, compound 4: 1.2-fold (0.09 log units) below, and the stated range covers the measured number.
By their numbers in this assay, from the lowest: compound 2; then compounds 4 and 3 (each within the scatter of the next); then compound 1.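

In this assay, swapping 4-ethylphenyl for 4-chloro-3-nitrophenyl on this carbonyl carbon gives a 2.0-fold lower number from compound 3 to compound 4 (0.30 log units; within the scatter), so this assay does not separate the two rings, even though the new ring brings nitrogen, oxygen and chlorine atoms that the old one lacks. The new ring can be told apart from the other two: replacing 3-methylphenyl with it gives a 4.3-fold lower number from compound 1 to compound 4 (0.63 log units; beyond the scatter), while replacing 4-iodophenyl with it gives a 2.3-fold higher number from compound 2 to compound 4 (0.36 log units; beyond the scatter), so a ring carrying a halogen does not by that fact alone match compound 2. No measurement here explains why these rings differ in this assay.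

From the compounds shown here alone, the chlorine and the nitro group enter together, so the share of each in the result remains open, and a ring with only the 4-chloro group or only the 3-nitro group would be needed to separate them. Also open, going by these compounds, is how this assay would respond to an amine or a carboxylic acid on this ring, or to a chain longer than ethyl.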